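Removing the Ring Methyl from a Morpholinyl Side Chain

A few compounds are considered here, and "the series" means these few. Any claim that something is new, unique, unknown or untested is made for them only; others in the source may bear on it.

Measured so far:
compound 1, `Cc1cc(Cl)cc(-c2ccnc3cc(CN4C(=O)C5C(C4=O)C5(C)C)sc23)c1C[C@@H]1CNCCO1`: 25 nM
compound 2, `Cc1cc(Cl)cc(-c2ccnc3cc(CN4C(=O)C5CC5C4=O)sc23)c1C[C@H]1OCCN[C@@H]1C`: 210 nM

In an assay on RKO cells for inhibition of ubiquitin carboxyl-terminal hydrolase 7 (Homo sapiens), read by a luciferase reporter, with a stated time of 18 h (on this read-out lower numbers stand for an effect already at smaller amounts and higher numbers for an effect only at larger amounts of compound), compound 2 gives the highest of the two numbers, its value lying beyond the scatter from compound 1. Compound 3, `Cc1cc(Cl)cc(-c2ccnc3cc(CN4C(=O)C5CC5C4=O)sc23)c1C[C@@H]1CNCCO1`, differs from compound 2 by hydrogen in place of methyl on a saturated ring carbon, 3-methylmorpholin-2-yl becoming morpholin-2-yl. Among the measured compounds shown here, compound 3 thereby shares this side chain with compound 1, though the two still differ elsewhere, so no single measured step isolates the change. The step from compound 2 to compound 3 is expected to lower the number, a 3.5-fold lower number from compound 2 to compound 3 (0.54 log units; beyond the scatter), beyond the scatter. Compound 3 is estimated at 60 nM, within 20 nM to 200 nM.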

Compound 3, half-maximal effective concentration: 35 nM
Compound 3: middle estimate off by 1.7-fold (0.23 log units), on the high side, within the range that was stated.
By their numbers in this assay, from the lowest: compounds 1 and 3 (each within the scatter of the next); then compound 2.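

Going from 3-methylmorpholin-2-yl to morpholin-2-yl gives a 6.0-fold lower number from compound 2 to compound 3 (0.78 log units; beyond the scatter) in this assay, so at this saturated ring carbon, next to the ring nitrogen, methyl gives a clearly higher number than hydrogen. With morpholin-2-yl held constant, the change in the group on the saturated chain carbon bound to an aromatic carbon gives a 1.4-fold higher number from compound 1 to compound 3 (0.15 log units; within the scatter), which does not separate these two compounds. Nothing available here explains the effect of the methyl. Still open, on these data alone, is how an ethyl or a hydroxymethyl at this ring carbon, or a methyl on the ring nitrogen, would read.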